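This account rests on a few compounds, and the source may have more. Where it says the series, first, only, none or still open, it means among the compounds named here.

The three measured compounds share one core and differ only in the group on the pendant ring. Compound 1 `COc1cccc(-c2nc3cccnc3o2)c1` gives 0% in a functional assay on the whole organism for inhibition, with Rattus norvegicus as the target, at a dose of 30 mg/kg; on this read-out lower numbers stand for less inhibition and higher numbers for more inhibition at the one dose given (going by the name of the read-out). Compound 2 `FC(F)(F)c1cccc(-c2nc3cccnc3o2)c1` gives 7% in this assay, and compound 3 `Cc1cccc(-c2nc3cccnc3o2)c1` gives 14%. Compound 3 is separated from compound 1 by a number 14 percentage points higher from compound 1 to compound 3 (beyond the scatter), a step beyond the scatter, while the difference a number 7 percentage points higher from compound 2 to compound 3 (within the scatter) lies within it, so compound 3 and compound 2 cannot be ranked against each other.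

Compound 4 `Clc1cccc(-c2nc3cccnc3o2)c1` is the next member of the series. Compared with compound 3 it differs by chloro in place of methyl on an aromatic carbon. All three measured steps exchange one group at this same aromatic carbon, and the largest of them, a number 14 percentage points higher from compound 1 to compound 3 (beyond the scatter), is only modest; the other two, a number 7 percentage points higher from compound 1 to compound 2 (within the scatter) and a number 7 percentage points higher from compound 2 to compound 3 (within the scatter), stay within the scatter. For the measured compounds named here, no measured step involves chloro. On that basis compound 4 is expected to give 12% in this assay, within 0% to 28%. The expected step from compound 3 is a number 2 percentage points lower from compound 3 to compound 4 (within the scatter), which is not expected to exceed the scatter.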

Compound 4, a percentage reported as inhibition, in the whole organism at one dose (the size of the read-out at that dose, not a potency): 8%
Estimate against measurement, compound 4: 4 percentage points above, within the range that was stated.
By their numbers in this assay, from the lowest: compounds 1, 2, 4 and 3 (each within the scatter of the next, the first and the last beyond it).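

Chloro is the first group at this aromatic carbon with a listed step to each of the other three groups, and in this assay all three stay within the scatter: a number 6 percentage points lower from compound 3 to compound 4 (within the scatter), a number 1 percentage points higher from compound 2 to compound 4 (within the scatter) and a number 8 percentage points higher from compound 1 to compound 4 (within the scatter). Compound 4 therefore cannot be ranked against compound 1, compound 2 or compound 3. For the compounds shown here, the exchange of methoxy for methyl remains the only step at this position that goes beyond the scatter, and nothing measured on these compounds bears on the result.

Going by these compounds, whether an amine, a carboxylic acid or a longer chain at this carbon would stand clearly apart from these four compounds remains open. Also open, on these data alone, is how any of these groups would behave at another dose, since the read-out gives the size of the effect at one dose only.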